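The compounds below may be only part of what the source reports. "The series", "measured", "known", "first", "only" and "open" are said of these compounds alone.

Compound 1, `C[Se]c1nc(N)c2ccccc2n1`, in a functional assay on CCRF-CEM cells (Homo sapiens) for cytotoxicity, read by MTT assay, with a stated time of 72 h (a higher number here means a weaker inhibitor of growth, a lower number a stronger inhibitor of growth), gives > 100000 nM, a limit of the assay rather than a number. Compound 2, `[SeH]c1nc([SeH])c2ccccc2n1`, gives 6010 nM. Compound 3, `CSc1nc(NCCCCc2ccccc2)c2ccccc2n1`, gives > 100000 nM, again a limit and not a number.

Within the data shown here, compound 2 therefore stands as the only compound of the three with a measured number in this assay; the other two values are limits, as described by the limit of > 100000 nM in this assay, at which 2 of the 3 values shown sit. Compound 4, `Nc1nc([SeH])nc2ccccc12`, is not yet measured. It differs from compound 2 in one place: one nitrogen atom in place of one selenium atom, on an aromatic carbon. In words, one nitrogen atom takes the place of one selenium atom on an aromatic carbon of the shared core.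

Among the measured compounds shown here, compound 1 also carries an amino group on its core and sits at the limit given by the limit of > 100000 nM in this assay, at which 2 of the 3 values shown sit, whereas compound 2, with two selenol groups, is the one compound with a number. On that basis the step is expected to run toward weaker growth inhibition, by a margin expected to exceed the scatter, and the estimated step of a 6.7-fold higher number from compound 2 to compound 4 (0.82 log units; beyond the scatter) reflects this. Compound 4 is accordingly expected to give about 40000 nM in this assay, within an estimated range from 8000 nM to 200000 nM, with a real chance that only a limit is reported.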

Compound 4, concentration for total growth inhibition: 52400 nM
Compound 4: the middle estimate sits 1.3-fold (0.12 log units) below what was measured, and the stated range covers the measured number.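

In this assay, among these compounds, the exchange of a selenium atom for an amino group on this aromatic carbon gives the first readable step: an 8.7-fold higher number from compound 2 to compound 4 (0.94 log units; beyond the scatter). The change therefore weakens growth inhibition by more than the scatter, yet compound 4 still returns a measured number, so an amino group at this position does not by itself bring a compound to the limit of the assay. The second step, with hydrogen in place of methyl on the selenium, is an at least 1.9-fold lower number from compound 1 to compound 4 (0.28 log units; that floor lies within the scatter), and as its floor lies within the scatter it does not establish on its own that this change matters, while its true size stays unread since the value of compound 1 is a limit and not a number: the limit of > 100000 nM in this assay, at which 2 of the 4 values shown sit.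

The compounds shown leave open how a hydroxyl group, a thiol or a methylamine at this position would compare with the selenium atom and the amino group. They also leave open whether a longer chain on the amino group of compound 4 would keep a measured number while the remaining selenium atom stays in place.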